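This account rests on a few compounds, and the source may have more. Where it says the series, first, only, none or still open, it means among the compounds named here.

Measured compounds:

Compound 1, `COc1ccc2c(c1)CCCN(CCCCN1CCN(c3ccccc3OC)CC1)C2=O`: 3 nM in an assay on CHO cells for displacement of a labelled ligand from D(4) dopamine receptor (Homo sapiens); a higher number here means a weaker inhibitor, a lower number a stronger inhibitor
Compound 2, `C#Cc1ccc2c(c1)CCN(CCCCN1CCN(c3ccccc3OC)CC1)C2=O`: 4.1 nM

Two compounds have been measured in this assay, and they give inhibition constants within the scatter of each other; nothing separates compound 1 from compound 2 on the numbers shown. Compound 2 is the one that carries the ethynyl group on the shared core, and it serves as the starting point for the next compound.

Compound 3, `COc1ccccc1N1CCN(CCCCN2CCc3cc(-c4ccco4)ccc3C2=O)CC1`, has not yet been measured. It differs from compound 2 in one place: furan-2-yl in place of ethynyl on an aromatic carbon. The change exchanges one small carbon substituent for a five-membered aromatic ring bearing one acceptor, on the same carbon of the core.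

For the measured compounds named here, no measured pair shows the effect of such an exchange, so the expected step has to rest on the two numbers available and on the modest size of the change. The step from compound 2 to compound 3 is estimated to be a 1.5-fold higher number from compound 2 to compound 3 (0.17 log units; within the scatter), a change not clearly beyond the scatter of this assay. For compound 3 the expected inhibition constant is 6 nM, within a range from 2 nM to 20 nM.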

Compound 3, inhibition constant: 3.3 nM
Beside the measured number, compound 3's estimate is 1.8-fold (0.26 log units) above it; low and high end bracket the measured number.
By their numbers in this assay, from the lowest: compounds 1, 3 and 2 (each within the scatter of the next).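

On the aromatic carbon that is meta to a fused ring and para to a fused ring, the replacement of ethynyl by furan-2-yl in this assay gives a 1.2-fold lower number from compound 2 to compound 3 (0.09 log units; within the scatter) and so leaves compound 2 and compound 3 indistinguishable. This position therefore accommodates a five-membered aromatic ring with 1 hetero atom as well as a triple-bonded substituent, and the added hydrogen-bond acceptor and extra heavy atoms of furan-2-yl are not separable from ethynyl in this pair. Nothing available accounts for this outcome.

As far as these compounds go, it remains open whether an amine or a carboxylic acid on the same aromatic carbon, or a larger aromatic group such as phenyl, would also stay within the scatter of compound 2 in this assay as furan-2-yl does. From the compounds shown here alone, it is also open whether furan-2-yl would behave the same way on the core of compound 1, which differs from compound 2 in more than one place and so cannot be compared with it directly.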